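Swapping the Ring on the Thiocarbonyl Carbon

The compounds below may be only part of what the source reports. "The series", "measured", "known", "first", "only" and "open" are said of these compounds alone.

Compound 1, `Cc1ccnc(/C(N)=N/NC(=S)N2CCCC2)c1`, in a functional assay on HeLa cells (Homo sapiens) for cytotoxicity, read by MTT assay, with a stated time of 72 h; on this read-out higher numbers stand for weaker inhibition and lower numbers for stronger inhibition: 1900 nM
Compound 2, `Cc1cccc(/C(N)=N/NC(=S)N2CCCC2)n1`, in this assay: 2700 nM

Of the compounds shown here, two have been measured so far. Compound 1 gives the smaller of the two numbers, but compound 2 lies within the usual scatter of it, so the two cannot be told apart on these data; neither can be called the more active one. For the measured compounds named here, no step between measured compounds differing in one place is available, so nothing yet shows how a change at the thiocarbonyl carbon moves the read-out.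

Compound 3, `Cc1ccnc(/C(N)=N/NC(=S)N2CCOCC2)c1`, has not been measured. It differs from compound 1 in one place: morpholin-4-yl in place of pyrrolidin-1-yl on a thiocarbonyl carbon. Compound 1 and compound 2 differ elsewhere, on the shared core, and say nothing about this position.

Going by the values given here, with no measured step to lean on, the expectation rests on the value of compound 1 alone. The number for compound 3 is expected to sit close to that of compound 1, with at most a small shift toward weaker inhibition, not beyond the scatter: the expected step is a 1.6-fold higher number from compound 1 to compound 3 (0.20 log units; within the scatter). Compound 3 is therefore estimated at 3000 nM, in a range from 1200 nM to 8000 nM.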

Compound 3, half-maximal inhibitory concentration: 38500 nM
The estimate for compound 3 lay 13-fold (1.11 log units) below the measured number, and the stated range ends below it.
By their numbers in this assay, from the lowest: compounds 1 and 2 (each within the scatter of the next); then compound 3.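

In this assay, the group on the thiocarbonyl carbon turns out to matter a great deal: morpholin-4-yl in place of pyrrolidin-1-yl gives a 20-fold higher number from compound 1 to compound 3 (1.31 log units; beyond the scatter) and so moves the read-out clearly toward weaker inhibition. For the compounds shown here, compounds 1 and 2 differ elsewhere on the shared core and could not show this, so this step is the first sign that the read-out responds to a change at this position, and that the pyrrolidin-1-yl ring is not freely exchangeable for another non-aromatic ring. No measurement at hand accounts for the size of this step.

The swap changes several things at once, as the ring goes from five-membered to six-membered, gains a second hetero atom and brings in a hydrogen-bond acceptor, and these compounds cannot separate those changes. On these data alone, it remains open whether piperidin-1-yl, a six-membered ring with no oxygen, would stay close to compound 1 or fall near compound 3, and whether the same swap on the core of compound 2 would give a step of similar size.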